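Two Anilide Hydantoins and an Untested Dichloro Analogue

The compounds below may be only part of what the source reports. "The series", "measured", "known", "first", "only" and "open" are said of these compounds alone.

Measured so far:
compound 1, `Cc1ccc(NC(=O)CN2C(=O)NC3(C2=O)c2ccccc2-c2ccccc23)cc1`: 53.4%
compound 2, `O=C(CN1C(=O)NC2(CCCCC2)C1=O)Nc1ccc(Br)cc1`: 85.1%

In a functional assay on the whole organism (strain BALB/c) with Mus musculus as the target, with a stated time of 8 h, at a dose of 10 mg/kg (a higher number here means more inhibition at the dose given (going by the name of the read-out), a lower number less inhibition), compound 2 gives 85.1%, the higher of the two numbers; compound 1 with 53.4% sits well below it, beyond the usual scatter. Compound 3, `O=C(CN1C(=O)NC2(CCCCC2)C1=O)Nc1ccc(Cl)cc1Cl`, is not yet measured. It differs from compound 2 in one place: 2,4-dichlorophenyl in place of 4-bromophenyl on an amide-type nitrogen. For the measured compounds named here, no measured pair shows what such a change does, so the step from compound 2 to compound 3 is expected to be small, a number 10.1 percentage points lower from compound 2 to compound 3 (beyond the scatter), with a slight downward lean because compound 2 already stands high at 85.1%. Compound 3 is therefore estimated at 75%, between 45% and 95%.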

Compound 3, a percentage reported as inhibition, in the whole organism at one dose (the size of the read-out at that dose, not a potency): 68.5%
The estimate for compound 3 lay 6.5 percentage points above the measured number; low and high end bracket the measured number.
By their numbers in this assay, from the lowest: compound 1; then compound 3; then compound 2.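

In this assay, the group on the amide-type nitrogen clearly matters: 2,4-dichlorophenyl in place of 4-bromophenyl gives a number 16.6 percentage points lower from compound 2 to compound 3 (beyond the scatter) with the rest of the molecule unchanged. For the compounds shown here, this pair is the only direct reading of that position, since compound 1 differs from the others in more than one place. No available evidence explains the drop. A 4-chlorophenyl group would help separate the change of halogen from the extra chlorine. Going by these compounds, how a plain phenyl or a methoxyphenyl group would read on this nitrogen also remains open.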